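Aryl swaps on the diaryl urea series: toward compound 4

This account rests on a few compounds, and the source may have more. Where it says the series, first, only, none or still open, it means among the compounds named here.

Measured compounds in a functional assay on PC-9 cells (Homo sapiens) for inhibition, read by MTT assay, with a stated time of 48 h, tested at 10 uM; a higher number here means more inhibition at the concentration tested (going by the name of the read-out), a lower number less inhibition:
compound 1 `COc1cc(NC(=O)Nc2cc(Nc3cccc(C(C)(C)C)c3)ncn2)cc(OC)c1` gives 68%
compound 2 `COc1cc(NC(=O)Nc2cc(Nc3ccc(C)c(F)c3)ncn2)cc(OC)c1` gives 77.5%
compound 3 `CCc1cccc(Nc2cc(NC(=O)Nc3cc(OC)cc(OC)c3)ncn2)c1` gives 82.1%

Compound 3 stands beyond the scatter above compound 1 and within the scatter of compound 2; no firm order between compound 2 and compound 3 can be read from these numbers. The step of a number 14.1 percentage points higher from compound 1 to compound 3 (beyond the scatter) came with ethyl in place of tert-butyl on an aromatic carbon, a modest change.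

The next compound, compound 4 `COc1cc(NC(=O)Nc2cc(Nc3ccc(Br)cc3OC)ncn2)cc(OC)c1`, is not yet measured. It differs from compound 3 by 4-bromo-2-methoxyphenyl in place of 3-ethylphenyl on a nitrogen on an aromatic ring.

Two measured steps exchange the whole aryl group on that same nitrogen and so bear directly on this change: a number 9.5 percentage points higher from compound 1 to compound 2 (within the scatter) and a number 4.6 percentage points higher from compound 2 to compound 3 (within the scatter), both within the scatter. The third step, a number 14.1 percentage points higher from compound 1 to compound 3 (beyond the scatter), is beyond the scatter but still modest. Exchanging the aryl group on this nitrogen has therefore shifted the read-out in this assay only a little so far, and nothing among the three compounds suggests a large move for the new group, in either direction. A step of no more than modest size, most likely within the scatter, is expected.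

Compound 4 is therefore estimated at 72%, with a range from 55% to 88%. This corresponds to an expected step of a number 10.1 percentage points lower from compound 3 to compound 4 (beyond the scatter).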

Compound 4, a percentage reported as inhibition, at one concentration (the size of the read-out at that concentration, not a potency): 83%
Beside the measured number, compound 4's estimate is 11 percentage points below it; measured number inside the range.
By their numbers in this assay, from the lowest: compounds 1, 2, 3 and 4 (each within the scatter of the next, the first and the last beyond it).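

Working notes on the aryl group on this nitrogen: in this assay the 4-bromo-2-methoxyphenyl group, the first here to bring in oxygen and bromine, gives a step of a number 0.9 percentage points higher from compound 3 to compound 4 (within the scatter) and a step of a number 5.5 percentage points higher from compound 2 to compound 4 (within the scatter), both within the scatter, so the change in atom types among these aryl groups leaves no readable difference among compound 2, compound 3 and compound 4. The step of a number 15 percentage points higher from compound 1 to compound 4 (beyond the scatter) lies beyond the scatter but is modest, which places the 3-(tert-butyl)phenyl group of compound 1 apart from compound 3 and compound 4, though not from compound 2, and that limits any pattern to those pairs. No measurement on hand bears on why the read-out holds across these different aryl groups.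

For the compounds shown here, the bromine and the methoxy arrive together in compound 4, so the contribution of each alone stays unresolved, and a single concentration gives no potency order for compounds this close. Also open, from the compounds shown here alone, is whether an aryl group on this nitrogen carrying an amine or a carboxylic acid would keep the read-out at this level.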